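Methoxy added to the fused ring: compound 2 to compound 4

The source may hold more compounds than are shown below. What is called first, only, known or untested is meant among the compounds shown, and "the series" means these compounds.

Measured in a functional assay on MCF7 cells (Homo sapiens) for inhibition, read by MTT assay, with a stated time of 24 h; a lower number here means a stronger inhibitor of growth, a higher number a weaker inhibitor of growth:
compound 1 `COc1ccccc1C(=O)n1c(-c2cn(C)c3ccccc23)nc2ccccc21`: 32100 nM
compound 2 `COc1cccc(C(=O)n2c(-c3cn(C)c4ccccc34)nc3ccccc32)c1`: 15700 nM
compound 3 `COc1ccc(C(=O)n2c(-c3cn(C)c4ccccc34)nc3ccccc32)cc1OC`: 10200 nM

The three measured compounds share one core and differ only in the methoxy pattern of the ring on the carbonyl carbon. Compound 2 holds the second highest of the three numbers: its nearest neighbour is compound 3, reached by a 1.5-fold lower number from compound 2 to compound 3 (0.19 log units; within the scatter), while compound 1 is furthest, with a 2.0-fold lower number from compound 1 to compound 2 (0.31 log units; beyond the scatter) separating the two.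

Compound 4 `COc1cccc(C(=O)n2c(-c3cn(C)c4ccc(OC)cc34)nc3ccccc32)c1` is not yet measured. It differs from compound 2 by methoxy in place of hydrogen on an aromatic carbon. For the measured compounds named here, the only measured step of the same kind is a 1.5-fold lower number from compound 2 to compound 3 (0.19 log units; within the scatter), but that methoxy entered the ring on the carbonyl carbon, not the fused system, and it stayed within the scatter. Going by the values given here, no measured step touches the fused system at all. On that basis a step of a 1.2-fold lower number from compound 2 to compound 4 (0.08 log units; within the scatter) is expected, not beyond the scatter. Compound 4 is therefore estimated at 13000 nM, with a range from 5000 nM to 35000 nM.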

Compound 4, concentration for 50% growth inhibition: 14600 nM
Beside the measured number, compound 4's estimate is 1.1-fold (0.05 log units) below it; low and high end bracket the measured number.
By their numbers in this assay, from the lowest: compounds 3, 4 and 2 (each within the scatter of the next); then compound 1.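

Methoxy in place of hydrogen on an aromatic carbon of the fused system, meta to a fused ring and para to a fused ring, gives a 1.1-fold lower number from compound 2 to compound 4 (0.03 log units; within the scatter) in this assay. This is the only change shown on the fused system, and at this one place methoxy leaves the number indistinguishable from that of compound 2, whereas moving the methoxy pattern on the ring on the carbonyl carbon gives a 3.1-fold lower number from compound 1 to compound 3 (0.50 log units; beyond the scatter). No data shown explain this result.

On these data alone, whether this place stays as unresponsive to a different group, such as an amine, a carboxylic acid or a longer alkoxy chain, remains open. Also open, as far as these compounds go, is whether methoxy on another carbon of the same ring would give a step beyond the scatter.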